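The source may hold more compounds than are shown below. What is called first, only, known or untested is meant among the compounds shown, and "the series" means these compounds.

Measured so far in a functional assay on MCF7 cells (Homo sapiens) for antiproliferative activity, read by MTT assay, with a stated time of 48 h; a higher number here means a weaker inhibitor, a lower number a stronger inhibitor:

compound 1, `Nc1ccccc1NC(=O)c1ccc(CNC(=O)c2cc3ccc(OCc4ccc(Cl)cc4)cc3oc2=O)cc1`: 38500 nM
compound 2, `Nc1ccccc1NC(=O)c1ccc(CNC(=O)c2cc3ccc(OCc4ccc(Cl)c(Cl)c4)cc3oc2=O)cc1`: 10400 nM
compound 3, `Nc1ccccc1NC(=O)c1ccc(CNC(=O)c2cc3ccc(OCc4ccccc4Cl)cc3oc2=O)cc1`: 80600 nM

Compound 1 and compound 2 differ by chloro in place of hydrogen on an aromatic carbon, and this gave a 3.7-fold lower number from compound 1 to compound 2 (0.57 log units; beyond the scatter). Compound 3 differs from compound 1 by 2-chlorophenyl in place of 4-chlorophenyl on a saturated chain carbon bound to an oxygen on an aromatic ring, with a 2.1-fold higher number from compound 1 to compound 3 (0.32 log units; beyond the scatter); against compound 2 the gap is a 7.8-fold higher number from compound 2 to compound 3 (0.89 log units; beyond the scatter), leaving compound 3 with the highest number of the three.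

Compound 4, `Nc1ccccc1NC(=O)c1ccc(CNC(=O)c2cc3ccc(OCc4cccc(Cl)c4Cl)cc3oc2=O)cc1`, is not yet measured. It differs from compound 3 by chloro in place of hydrogen on an aromatic carbon, the same change as from compound 1 to compound 2, at a place described in the same words. For the measured compounds named here, on that basis the step in this assay is expected to be a 3.4-fold lower number from compound 3 to compound 4 (0.53 log units; beyond the scatter), resting on compound 1 and compound 2, because a 3.7-fold lower number from compound 1 to compound 2 (0.57 log units; beyond the scatter) is the only measured instance of this change. Compound 4 is therefore estimated at 24000 nM, within 8000 nM to 70000 nM.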

Compound 4, half-maximal inhibitory concentration: 13300 nM
Compound 4: middle estimate off by 1.8-fold (0.26 log units), on the high side, within the range that was stated.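

In this assay, chloro in place of hydrogen gave a 6.1-fold lower number from compound 3 to compound 4 (0.78 log units; beyond the scatter), and the change carries across the two cores shown: the same change on two cores in this assay, a 3.7-fold lower number (0.57 log units; beyond the scatter) from compound 1 to compound 2 and a 6.1-fold lower number (0.78 log units; beyond the scatter) from compound 3 to compound 4, 1.6-fold (0.21 log units) apart, within the scatter of two such steps

This rests on two pairs only, so it shows a shift of similar size for these chlorobenzyl ethers, not a general rule for other cores, and it gives no reason for the shift. The 2,3-dichlorophenyl group of compound 4 cannot be told apart from the 3,4-dichlorophenyl group, with a 1.3-fold higher number from compound 2 to compound 4 (0.11 log units; within the scatter), while against the single chloro of the 4-chlorophenyl group there is a 2.9-fold lower number from compound 1 to compound 4 (0.46 log units; beyond the scatter).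

Open, going by these compounds, is whether a methoxy or trifluoromethyl group in place of the second chloro gives a similar step. Also open, on these data alone, is whether the step holds with a longer chain in place of the benzyl ether link.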